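The source may hold more compounds than are shown below. What is called first, only, known or untested is meant among the compounds shown, and "the series" means these compounds.

Measured so far in a functional assay on T47D cells (Homo sapiens) for cytotoxicity, read by MTT assay, with a stated time of 24 h; on this read-out lower numbers stand for stronger inhibition and higher numbers for weaker inhibition:
Compound 1, `COc1ccc(/C=C\C(=O)O)c(OCc2cn(-c3ccccc3C(=O)N3CCC(O)C3)nn2)c1CC=C(C)C`, gives 13400 nM.
Compound 2, `COc1ccc(/C=C\C(=O)O)c(OCc2cn(-c3ccc(NC(C)=O)cc3)nn2)c1CC=C(C)C`, gives 17400 nM.
Compound 3, `COc1ccc(/C=C\C(=O)O)c(OCc2cn(-c3cccc(C#N)c3)nn2)c1CC=C(C)C`, gives 19200 nM.

Compound 2 stands second highest of the three numbers; compound 3 lies nearest and compound 1 furthest, both within the scatter. Compound 4, `COc1ccc(/C=C\C(=O)O)c(OCc2cn(-c3ccc(C#N)cc3)nn2)c1CC=C(C)C`, differs from compound 2 by cyano in place of acetamido on an aromatic carbon, which read one bond further out is 4-acetamidophenyl to 4-cyanophenyl. For the measured compounds named here, the only measured step bearing on this is a 1.1-fold higher number from compound 2 to compound 3 (0.04 log units; within the scatter), where 3-cyanophenyl replaced the same 4-acetamidophenyl and the number stayed within the scatter. No shift beyond the scatter is therefore expected in this assay, and the expected step is a 1.0-fold lower number from compound 2 to compound 4 (0.01 log units; within the scatter). Compound 4 is estimated at 17000 nM, with a range from 9000 nM to 34000 nM.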

Compound 4, half-maximal inhibitory concentration: 10200 nM
Beside the measured number, compound 4's estimate is 1.7-fold (0.22 log units) above it; the measured number falls inside the stated range.
By their numbers in this assay, from the lowest: compounds 4, 1, 2 and 3 (each within the scatter of the next).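

In this assay, cyano in place of acetamido on the aromatic carbon para to a large group gives a 1.7-fold lower number from compound 2 to compound 4 (0.23 log units; within the scatter), so this exchange of groups stays within the scatter. With 4-cyanophenyl in place of 3-cyanophenyl, the comparison gives a 1.9-fold lower number from compound 3 to compound 4 (0.27 log units; within the scatter), so the two nitrile placements shown cannot be told apart in this assay. Nothing available here bears on why these numbers fall where they do.

Going by these compounds, whether an amine, a carboxylic acid or a longer chain at this position would give a step beyond the scatter remains open.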